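Methyl in place of ethoxy: compound 2 to compound 3

A few compounds are considered here, and "the series" means these few. Any claim that something is new, unique, unknown or untested is made for them only; others in the source may bear on it.

On these data alone, two members have been measured, compound 1 (`COc1ccc(/C=C/[C@@](C)(/C=C/c2ccc(O)c(/C=C/C#N)c2)CCC=C(C)C)cc1`) and compound 2 (`CCOc1ccc(/C=C/[C@@](C)(/C=C/c2ccc(O)cc2)CCC=C(C)C)cc1`), while compound 3 (`CC(C)=CCC[C@@](C)(/C=C/c1ccc(C)cc1)/C=C/c1ccc(O)cc1`) remains open. In a functional assay on HepG2 cells (Homo sapiens) for cytotoxicity, with a stated time of 72 h (a higher number here means that more compound is needed for the effect, a lower number that less compound is needed), compound 1 gives > 26000 nM, which is a limit of the assay and not a number. In this assay compound 2 gives > 52000 nM, which is also a limit, so compound 2 has no exact value. The next structural change, from compound 2 to compound 3, places methyl in place of ethoxy on an aromatic carbon, para to a large group (methyl in place of ethoxy on an aromatic carbon). No measured step sizes this change. With compound 2 standing at > 52000 nM, no shift beyond the scatter is expected in this assay, and no direction is favoured. The estimated change is an at least 1.0-fold lower number from compound 2 to compound 3 (0.01 log units; that floor lies within the scatter). Compound 3 is expected at 50000 nM, with an estimated range of 20000 nM to 100000 nM.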

Compound 3, half-maximal effective concentration: > 52000 nM
Compound 3: no number, only a limit (the forecaster's own chance of this, stated with the estimate: 75%); at least 1.0-fold (0.01 log units) between middle value and limit.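

No step can be read from compound 2 to compound 3 in this assay: each compound carries only a limit of the assay, not a number. The compounds shown leave open whether methyl in place of ethoxy on an aromatic carbon shifts this read-out at all.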